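The compounds below may be only part of what the source reports. "The series", "measured", "known", "first", "only" and "open" are said of these compounds alone.

Measured so far in an ADME assay on TZM cells (Homo sapiens) for cytotoxicity; a lower number here means that less compound is tolerated, a higher number that more compound is tolerated:
Compound 1 `CC(C)c1c(OC2CCCCC2C)cc(Cc2ccc(Cl)cc2)[nH]c1=O`: 109000 nM
Compound 2 `CC(C)c1c(OC2CCCCC2C)cc(Cc2ccc(F)cc2)[nH]c1=O`: 74500 nM

Compound 2 stands at 74500 nM, within the scatter of compound 1. The next compound, compound 3 `Cc1ccc(Cc2cc(OC3CCCCC3C)c(C(C)C)c(=O)[nH]2)cc1`, has methyl in place of fluoro on an aromatic carbon, para to a large group: methyl in place of fluoro on an aromatic carbon. The change reads 4-fluorobenzyl to 4-methylbenzyl, and the rest of the structure stays the same. Going by the values given here, one measured step bears on it, at the same aromatic carbon: a 1.5-fold lower number from compound 1 to compound 2 (0.17 log units; within the scatter). Among the compounds with values here, that exchange of chloro for fluoro stayed within the scatter, but no methyl compound has been measured yet, so the evidence is thin. No change beyond the scatter is therefore expected in this assay. The expected size is a 1.1-fold higher number from compound 2 to compound 3 (0.06 log units; within the scatter). Compound 3 is estimated at 85000 nM, with an expected range from 40000 nM to 170000 nM.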

Compound 3, half-maximal cytotoxic concentration: 99000 nM
Beside the measured number, compound 3's estimate is 1.2-fold (0.07 log units) below it; low and high end bracket the measured number.
By their numbers in this assay, from the lowest: compounds 2, 3 and 1 (each within the scatter of the next).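

In this assay, methyl now stands with fluoro and chloro at this aromatic carbon, and the change of group again moves the number little: methyl in place of fluoro gives a 1.3-fold higher number from compound 2 to compound 3 (0.12 log units; within the scatter), while methyl in place of chloro gives a 1.1-fold lower number from compound 1 to compound 3 (0.04 log units; within the scatter) and stays just as close. The exchange at this position is therefore no longer seen only between two halogens, since a carbon group sits there too with no step beyond the scatter. Nothing on hand offers a reason for this closeness.

Still open, going by these compounds, is whether the number would stay this flat with a group of another kind at the same carbon, such as an amine, a carboxylic acid or a longer chain. On these data alone, the rest of the structure is the same in all three compounds, so how changes elsewhere would read remains unknown.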